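Aryl swap on the shared core: tert-butylphenyl variant

A few compounds are considered here, and "the series" means these few. Any claim that something is new, unique, unknown or untested is made for them only; others in the source may bear on it.

The three measured compounds share the core of compound 1 `COc1cc(-c2ccnc3cc(-c4ccc(C)c(C)c4)nn23)cc(OC)c1OC` and differ only in the aryl group attached to it. Among the measured compounds shown here, in a functional assay on HCT-116 cells (Homo sapiens) for inhibition, read by CCK-8 assay, with a stated time of 48 h (on this read-out higher numbers stand for weaker inhibition and lower numbers for stronger inhibition), compound 1 gives 261 nM, the second highest of the three numbers so far. Compound 2 `COc1cc(-c2ccnc3cc(-c4ccc5cc[nH]c5c4)nn23)cc(OC)c1OC` gives 187 nM in this assay, and compound 3 `COc1ccc(-c2cc3nccc(-c4cc(OC)c(OC)c(OC)c4)n3n2)cc1F` gives 2840 nM. Of the measured steps, a 1.4-fold lower number from compound 1 to compound 2 (0.14 log units; within the scatter) stays within the scatter, whereas an 11-fold higher number from compound 1 to compound 3 (1.04 log units; beyond the scatter) and a 15-fold higher number from compound 2 to compound 3 (1.18 log units; beyond the scatter) are large and beyond it.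

Compound 4 `COc1cc(-c2ccnc3cc(-c4ccc(C(C)(C)C)cc4)nn23)cc(OC)c1OC` differs from compound 1 in one place: 4-(tert-butyl)phenyl in place of 3,4-dimethylphenyl on an aromatic carbon. For the measured compounds named here, the step that bears most directly on it is the one from compound 1 to compound 2, where a different aryl group on the same position left the number within the scatter; the large rises to compound 3 both involve 3-fluoro-4-methoxyphenyl, a group compound 4 does not carry. On this basis no step beyond the scatter is expected in this assay for compound 4 in either direction. Compound 4 is therefore expected to give 300 nM in this assay, within a range from 120 nM to 800 nM. The expected step is a 1.1-fold higher number from compound 1 to compound 4 (0.06 log units; within the scatter).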

Compound 4, half-maximal inhibitory concentration: > 10000 nM
Compound 4: only a limit was reported; the forecaster's own chance of this, stated with the estimate: 2%; middle value at least 33-fold (1.52 log units) from the limit.
By their numbers in this assay, from the lowest: compounds 2 and 1 (each within the scatter of the next); then compound 3. At a limit, above all of these: compound 4.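

In this assay compound 4 stands at a limit and not at a number: the limit of > 10000 nM in this assay, at which 1 of the 4 values shown sits.

The position on the five-membered aromatic ring proves far less permissive than the step from compound 1 to compound 2 suggested, since an at least 38-fold higher number from compound 1 to compound 4 (1.58 log units; beyond the scatter) separates two groups that each hold one six-membered aromatic ring of carbon only, with no hydrogen-bond donor or acceptor and no net charge, so these counts do not tell the two groups apart. The 4-(tert-butyl)phenyl group also falls behind the other two aryl groups, with an at least 53-fold higher number from compound 2 to compound 4 (1.72 log units; beyond the scatter) and an at least 3.5-fold higher number from compound 3 to compound 4 (0.54 log units; beyond the scatter), which places compound 4, not compound 3 with its 3-fluoro-4-methoxyphenyl group, at the weak end of the series, and all three steps are lower bounds only.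

The compounds shown cannot separate the tert-butyl group itself from its placement on the phenyl ring, and they do not tell how far compound 4 lies past its limit. An isopropyl or methyl group in place of the tert-butyl, or an amine on the same phenyl ring, would remain to be compared at this position.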